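From compound 2 to compound 3: swapping the ring group

The source may report more compounds than this note shows. Statements on the series, on what has been measured and on what is new or still open speak of the compounds shown alone.

Among the compounds with values here, in a physicochemical assay for solubility, in phosphate buffer, measured as kinetic solubility, at pH 7.4 (a higher number here means a more soluble compound, a lower number a less soluble compound), compound 2 `Cc1ccccc1-c1nc(CN2CCC(C(=O)NCCCN3CCCC(CC(C)C)C3)CC2)c(C)o1` gives 54.9 ug/mL, the only number so far. Compound 1 `Cc1ccccc1-c1nc(CN2CCC(C(=O)NCCCN3[C@H](C)CCC[C@@H]3C)CC2)c(C)o1` gives > 69 ug/mL, which is a limit of the assay and not a number.

Compound 3 `Cc1ccccc1-c1nc(CN2CCC(C(=O)NCCN3C[C@H](C)C[C@H](C)C3)CC2)c(C)o1` differs from compound 2 by a group of 8 heavy atoms (7 carbon, 1 nitrogen; one six-membered non-aromatic ring with 1 hetero atom) in place of a group of 11 heavy atoms (10 carbon, 1 nitrogen; one six-membered non-aromatic ring with 1 hetero atom), on a saturated chain carbon, two bonds along the chain from an amide-type nitrogen. The entering group is 3,5-dimethylpiperidin-1-yl, with 2 defined stereocentres, on a saturated chain carbon, two bonds along the chain from an amide-type nitrogen.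

Within the data shown here, one measured step bears on this, as it also exchanges one such ring group for another: an at least 1.2-fold lower number from compound 1 to compound 2 (0.09 log units; that floor lies within the scatter). That single floor gives only weak guidance, so no step beyond the scatter is expected in this assay. The estimated step is a 1.1-fold higher number from compound 2 to compound 3 (0.05 log units; within the scatter), which stays within the scatter. Compound 3 is expected at 62 ug/mL, with an estimated range of 35 ug/mL to 95 ug/mL.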

Compound 3, solubility: > 67 ug/mL
Compound 3 ended at the assay's limit (the forecaster's own chance of this, stated with the estimate: 40%); at least 1.0-fold (0.03 log units) between middle value and limit.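

In this assay, replacing the group of 11 heavy atoms with 3,5-dimethylpiperidin-1-yl, on a saturated chain carbon, two bonds along the chain from an amide-type nitrogen, gives an at least 1.2-fold higher number from compound 2 to compound 3 (0.08 log units; that floor lies within the scatter), so this smaller group shows no change beyond the scatter, and the figure is a floor rather than a measured size. Compound 3 carries a limit of the assay, not a number: the limit of > 67 ug/mL in this assay, at which 1 of the 3 values shown sits. Compound 1 also carries a limit of the assay, not a number: the limit of > 69 ug/mL in this assay, at which 1 of the 3 values shown sits.

The step between compound 1 and compound 3 cannot be read, as each end of it is a limit. From the compounds shown here alone, whether a morpholine ring or a piperazine ring at this place would give a true number in this assay remains open.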